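The source may report more compounds than this note shows. Statements on the series, on what has been measured and on what is new or still open speak of the compounds shown alone.

Compound 1 `Cc1cc(Nc2ccc(C(=O)/C=C/c3cccc(Br)n3)cc2)n2nc(SCc3ccc(F)cc3)nc2n1` gives 93.3% in a functional assay on MGC-803 cells (Homo sapiens) for inhibition, read by sulforhodamine B assay, with a stated time of 72 h, tested at 10 uM; on this read-out lower numbers stand for less inhibition and higher numbers for more inhibition at the one concentration tested (going by the name of the read-out). Compound 2 `Cc1cc(Nc2ccc(C(=O)/C=C/c3cccc(Br)n3)cc2)n2nc(SCc3ccc(Br)cc3)nc2n1` gives 96.3% in this assay.

Compound 2 lies within the scatter of compound 1, so the two cannot be told apart, as a number 3 percentage points higher from compound 1 to compound 2 (within the scatter) shows. Compound 3 `Cc1cc(Nc2ccc(C(=O)/C=C/c3cccc(Br)n3)cc2)n2nc(SCc3ccc([N+](=O)[O-])cc3)nc2n1` has not yet been measured. Its difference from compound 2 is nitro in place of bromo on an aromatic carbon. For the measured compounds named here, the one measured step swaps one halogen for another at the same place and says nothing about a nitro group, so no measured step bears directly on this change. Because compound 1 gives 93.3% and compound 2 gives 96.3%, compound 3 is expected to land near them, with an estimated step of a number 6.3 percentage points lower from compound 2 to compound 3 (within the scatter) and a wide margin. Compound 3 is estimated at 90%, between 72% and 98%.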

Compound 3, a percentage reported as inhibition, at one concentration (the size of the read-out at that concentration, not a potency): 91.6%
Beside the measured number, compound 3's estimate is 1.6 percentage points below it, and the stated range covers the measured number.
By their numbers in this assay, from the lowest: compounds 3, 1 and 2 (each within the scatter of the next).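

Replacing the halogen with nitro on this aromatic carbon gives a number 4.7 percentage points lower from compound 2 to compound 3 (within the scatter) and a number 1.7 percentage points lower from compound 1 to compound 3 (within the scatter) in this assay. The earlier pair compared only two halogens, whereas these steps show that a non-halogen group with more heavy atoms and two hydrogen-bond acceptors also cannot be told apart from them at this position. None of the data shown explain why the three compounds read alike.

From the compounds shown here alone, an amine, a carboxylic acid or a longer chain at this place remains open. So does whether any of them would give a reading outside the scatter of these three compounds.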